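A few compounds are considered here, and "the series" means these few. Any claim that something is new, unique, unknown or untested is made for them only; others in the source may bear on it.

Working notes on the series. Compound 1 `COC(=O)C1=C(C)N=C(C)/C(=C(/O)OC)C1c1cccc(N/C(=N/CCNC2CCN(c3ccccc3O)CC2)NC#N)c1` and compound 3 `COC(=O)C1=C(C)N=C(C)/C(=C(/O)OC)C1c1cccc(NC(=O)NCCNC2CCN(c3ccccc3O)CC2)c1` share the same core apart from one portion; the difference between the two cores is not broken down here. In an assay on SK-N-MC cells for inhibition of Neuropeptide Y receptor type 1 (Homo sapiens) (on this read-out lower numbers stand for stronger inhibition and higher numbers for weaker inhibition), compound 1 gives 5 nM and compound 3 gives 6 nM, two values that sit within the scatter of each other. Compound 2 `COC(=O)C1=C(C)N=C(C)/C(=C(/O)OC)C1c1cccc(N/C(=N/CCNC2CCN(c3cccc(Cl)c3)CC2)NC#N)c1` carries 3-chlorophenyl in place of 2-hydroxyphenyl on an amine nitrogen in a ring relative to compound 1, and in this assay compound 2 gives 8 nM. The step of a 1.6-fold higher number from compound 1 to compound 2 (0.20 log units; within the scatter) is within the scatter. Compound 4 `COC(=O)C1=C(C)N=C(C)/C(=C(/O)OC)C1c1cccc(NC(=O)NCCNC2CCN(c3cccc(Cl)c3)CC2)c1` has not yet been measured in this assay. For the measured compounds named here, it carries 3-chlorophenyl in place of 2-hydroxyphenyl on an amine nitrogen in a ring relative to compound 3, the same change as the one from compound 1 to compound 2, at the same place. The expectation for compound 4 rests on compound 3 with its value 6 nM and on the earlier step of a 1.6-fold higher number from compound 1 to compound 2 (0.20 log units; within the scatter). A step of a 1.5-fold higher number from compound 3 to compound 4 (0.18 log units; within the scatter) is expected, beside the earlier one. Compound 4 is therefore estimated at 9 nM, with an expected range from 4 nM to 20 nM.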

Compound 4, half-maximal inhibitory concentration: 8 nM
Beside the measured number, compound 4's estimate is 1.1-fold (0.05 log units) above it, within the range that was stated.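

In this assay the exchange of 2-hydroxyphenyl for 3-chlorophenyl on an amine nitrogen in a ring gives a 1.3-fold higher number from compound 3 to compound 4 (0.12 log units; within the scatter). Set beside the earlier step, the exchange reads alike on the two cores: the same change on two cores in this assay, a 1.6-fold higher number (0.20 log units; within the scatter) from compound 1 to compound 2 and a 1.3-fold higher number (0.12 log units; within the scatter) from compound 3 to compound 4, 1.2-fold (0.08 log units) apart, within the scatter of two such steps

On these two cores, then, the exchange carries over with no step beyond the scatter, but this is agreement between two small steps, and it does not show how a larger step would carry over or whether the exchange would behave the same way on any further core. The compounds shown leave open how a benzyl group or a plain methyl group on that ring nitrogen would read in this assay, since only 2-hydroxyphenyl and 3-chlorophenyl stand there. They also leave open whether a longer chain in the linker would keep the two cores in step.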